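Swapping chloro for fluoro in a level series

The source may hold more compounds than are shown below. What is called first, only, known or untested is meant among the compounds shown, and "the series" means these compounds.

Compound 3 `O=c1oc2ccccc2c2nc3c(ccc4cc[nH]c43)c(-c3ccc(Cl)cc3)c12` carries a 4-chlorophenyl group on the shared core, and in a functional assay on B16-F10 cells (Mus musculus) for cytotoxicity (a higher number here means a weaker inhibitor, a lower number a stronger inhibitor), compound 3 gives 70700 nM. That puts it level with its two measured relatives. Compound 1 `O=c1oc2ccccc2c2nc3c(ccc4cc[nH]c43)c(-c3cccc(Br)c3)c12`, which has a 3-bromophenyl group instead, gives 70700 nM, and compound 2 `O=c1oc2ccccc2c2nc3c(ccc4cc[nH]c43)c(-c3ccccc3Br)c12`, with a 2-bromophenyl group, gives 70700 nM.

The next compound, compound 4 `O=c1oc2ccccc2c2nc3c(ccc4cc[nH]c43)c(-c3ccc(F)cc3)c12`, differs from compound 3 in a single atom: fluoro in place of chloro on an aromatic carbon, para to a large group (fluoro in place of chloro on an aromatic carbon). Among the compounds with values here, three measured steps bear on this change, as each alters the same substituted phenyl group: no change at the digits printed from compound 1 to compound 2 (within the scatter), no change at the digits printed from compound 1 to compound 3 (within the scatter) and no change at the digits printed from compound 2 to compound 3 (within the scatter). Across these three compounds, neither moving the bromo group nor exchanging it for chloro at another place separated the values in this assay. Within the data shown here, no measured step exchanges chloro for fluoro directly, so this comparison is only an indirect guide. On that evidence, no step beyond the scatter is expected, and so no direction is predicted. The estimate amounts to no change at the digits printed from compound 3 to compound 4 (within the scatter). For compound 4 the estimated value is 70700 nM, with an expected range from 35000 nM to 100000 nM.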

Compound 4, half-maximal inhibitory concentration: 70700 nM
The estimate for compound 4 equals the measured number at the digits printed; the range from low to high includes it.
By their numbers in this assay, from the lowest: compounds 1, 2, 3 and 4 (each within the scatter of the next).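

In this assay, the direct exchange of chloro for fluoro on this aromatic carbon, para to a large group, gives no change at the digits printed from compound 3 to compound 4 (within the scatter) and so adds fluoro to bromo and chloro as a third halogen that does not separate the values on this phenyl group. The wider comparisons agree: 4-fluorophenyl in place of 2-bromophenyl gives no change at the digits printed from compound 2 to compound 4 (within the scatter) and 4-fluorophenyl in place of 3-bromophenyl gives no change at the digits printed from compound 1 to compound 4 (within the scatter) and leaves all four compounds level, with none going against that pattern. Nothing measured here accounts for why these halogen exchanges leave the number where it is.

Every compound shown carries one halogen on the phenyl group, so the result says nothing about a phenyl group with no substituent or about a group of a different kind, such as an amine, a carboxylic acid or a longer chain. It also leaves open whether fluoro would read the same at the other places on the ring, where only bromo appears among these compounds.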